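Azole swap on the thioether arm of compound 3

The source may report more compounds than this note shows. Statements on the series, on what has been measured and on what is new or still open speak of the compounds shown alone.

Of the compounds shown here, three so far carry a number in a functional assay on C6 cells (Rattus norvegicus) for cytotoxicity, read by MTT assay, with a stated time of 24 h, tested at 200 ug/mL; a lower number here means a stronger effect, a higher number a weaker effect of the compound at the concentration tested. Compound 1 `O=C(CSc1nnnn1-c1ccccc1)N/N=c1/scc(-c2ccc(Br)cc2)n1-c1ccccc1` gives 20.4%. Compound 2 `Cc1ccc(-c2cs/c(=N/NC(=O)CSc3nnnn3-c3ccccc3)n2-c2ccccc2)cc1` gives 22.2%, and the step of a number 1.8 percentage points higher from compound 1 to compound 2 (within the scatter) stays within the scatter. Compound 3 `Cc1ccc(-c2cs/c(=N/NC(=O)CSc3nncn3C)n2-c2ccccc2)cc1` gives 27.8%, and the step of a number 5.6 percentage points higher from compound 2 to compound 3 (within the scatter) again stays within the scatter. Compound 3 thus holds the highest of the three numbers, yet its gaps to compound 2 and to compound 1 both lie inside the scatter, so no order among the three can be drawn from them.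

Compound 4 `Cc1ccc(-c2cs/c(=N/NC(=O)CSc3nnnn3C)n2-c2ccccc2)cc1` differs from compound 3 in one place: 1-methyl-1H-tetrazol-5-yl in place of 4-methyl-4H-1,2,4-triazol-3-yl on a sulfur. The change sits on a sulfur whose other neighbour is a saturated chain carbon; cut one bond further out it reads (4-methyl-4H-1,2,4-triazol-3-yl)sulfanyl to (1-methyl-1H-tetrazol-5-yl)sulfanyl.

Going by the values given here, the only measured step at this sulfur was a number 5.6 percentage points higher from compound 2 to compound 3 (within the scatter); the other measured step, on an aromatic carbon, was a number 1.8 percentage points higher from compound 1 to compound 2 (within the scatter). Both stayed within the scatter, and the present change again swaps one small azole for another, so no step beyond the scatter is expected in this assay. Compound 4 is therefore expected to show a number 1.8 percentage points lower from compound 3 to compound 4 (within the scatter). Compound 4 is estimated at 26%, with a range from 16% to 36%.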

Compound 4, a percentage reported as activity, at one concentration (the size of the read-out at that concentration, not a potency): 39.7%
The estimate for compound 4 lay 13.7 percentage points below the measured number; the whole stated range lies below it.
By their numbers in this assay, from the lowest: compounds 1, 2 and 3 (each within the scatter of the next); then compound 4.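

Working notes: the sulfur position can move the read-out beyond the scatter, and the azole attached there matters even when the replacement is small. In this assay, 1-methyl-1H-tetrazol-5-yl in place of 4-methyl-4H-1,2,4-triazol-3-yl gives a number 11.9 percentage points higher from compound 3 to compound 4 (beyond the scatter), whereas the earlier exchange at this sulfur gave a number 5.6 percentage points higher from compound 2 to compound 3 (within the scatter). With the tetrazole held, methyl in place of phenyl on an aromatic nitrogen gives a number 17.5 percentage points higher from compound 2 to compound 4 (beyond the scatter), so the group on that nitrogen also counts, and the higher number means a weaker effect at the concentration tested. No evidence on the origin of these steps is at hand.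

Open, going by these compounds, is whether the step from methyl to phenyl on the tetrazole nitrogen is graded, as an ethyl or a propyl group there would show, and whether an amine or a carboxylic acid on that chain would shift the number further. Also open, on these data alone, is whether the bromo group on the aromatic carbon, in place of methyl, leaves the number of the methyl tetrazole within the scatter, as it did for the phenyl tetrazole.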